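Sulfonyl aryl swap on the shared core: compound 2 to 3

This account rests on a few compounds, and the source may have more. Where it says the series, first, only, none or still open, it means among the compounds named here.

Measured so far:
compound 1, `CC1CCN(c2c(S(=O)(=O)c3ccc(F)c(F)c3)cnc3ccc(F)cc23)CC1`, 82%
compound 2, `Cc1ccc(S(=O)(=O)c2cnc3ccc(Cl)cc3c2N2CCC(C)CC2)cc1`, 95%

In an assay on isolated protein for displacement of a labelled ligand from metabotropic glutamate receptor 5 (Homo sapiens), with a stated time of 60 min, tested at 1 uM (on this read-out lower numbers stand for less inhibition and higher numbers for more inhibition at the one concentration tested (going by the name of the read-out)), compound 2 gives 95%, the higher of the two numbers recorded. The nearest number is that of compound 1, which in this assay gives 82%, a gap that lies beyond the scatter of repeated runs. Within the data shown here, no step between the two measured compounds can be isolated, since they differ in more than one place; the two values are simply what they show.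

Compound 3, `CC1CCN(c2c(S(=O)(=O)c3ccc(F)c(F)c3)cnc3ccc(Cl)cc23)CC1`, has not yet been measured. It differs from compound 2 in one place:

3,4-difluorophenyl in place of 4-methylphenyl on a sulfonyl sulfur

Compound 1 also carries a 3,4-difluorophenyl on its sulfonyl sulfur and sits at the lower of the two numbers, so a modest drop from compound 2 is taken as the more likely direction for this assay, though a result within the scatter cannot be excluded. The step from compound 2 to compound 3 is expected to be a number 7 percentage points lower from compound 2 to compound 3 (within the scatter). For compound 3 the estimate in this assay is 88%, with a range of 76% to 97%.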

Compound 3, a percentage reported as inhibition, at one concentration (the size of the read-out at that concentration, not a potency): 72%
Estimate against measurement, compound 3: 16 percentage points above; the whole stated range lies above it.
By their numbers in this assay, from the lowest: compounds 3 and 1 (each within the scatter of the next); then compound 2.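

In this assay, among these compounds, 3,4-difluorophenyl in place of 4-methylphenyl on a sulfonyl sulfur gives a number 23 percentage points lower from compound 2 to compound 3 (beyond the scatter); this is the first change at this position that can be read on its own, and it shows that the aryl group on the sulfonyl sulfur matters to this read-out with the rest of the structure held constant. With the 3,4-difluorophenyl kept, chloro in place of fluoro on an aromatic carbon gives a number 10 percentage points lower from compound 1 to compound 3 (within the scatter), so of the two single changes now available, only the sulfonyl aryl swap stands beyond the scatter. Nothing at hand bears on why the aryl swap shifts the number.

Among the compounds shown here, only two aryl groups on the sulfonyl sulfur appear here, so it remains open how a 4-methoxyphenyl or an unsubstituted phenyl would read at this position, and whether the 4-methylphenyl advantage holds with fluoro rather than chloro on the shared core. All of these numbers are percentages at a single concentration, so they leave the potency of each compound open, and the size of the aryl step may look different on a full concentration curve.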